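The compounds below may be only part of what the source reports. "The series", "measured", "known", "first", "only" and "open" are said of these compounds alone.

The measured compounds are:

- compound 1, `CC1(C)O[C@@H](CO)[C@H](Cn2cc(Cn3c4c(c5ccccc53)C(=O)c3c[n+]([O-])c5ccccc5c3C4=O)nn2)O1`, which in a functional assay on MCF7 cells (Homo sapiens) for cytotoxicity, read by MTT assay, with a stated time of 72 h (on this read-out lower numbers stand for stronger inhibition and higher numbers for weaker inhibition), gives 690 nM
- compound 2, `O=C1c2c[n+]([O-])c3ccccc3c2C(=O)c2c1c1ccccc1n2CCCCN1CCCCC1`, which gives 150 nM
- compound 3, `CN(C)CCCCn1c2c(c3ccccc31)C(=O)c1c[n+]([O-])c3ccccc3c1C2=O`, which gives 220 nM

All three share the same core and differ only in the group attached to the aromatic nitrogen. Compound 1 gives the highest number of the three, meaning the weakest inhibition: its nearest neighbour is compound 3, and compound 2 stands further away, both gaps lying beyond the usual scatter of the measurement. For the measured compounds named here, the one directly comparable pair is compound 2 against compound 3, where the change is a 1.5-fold higher number from compound 2 to compound 3 (0.17 log units; within the scatter).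

Compound 4 is `CC1(C)OC[C@H](Cn2cc(Cn3c4c(c5ccccc53)C(=O)c3c[n+]([O-])c5ccccc5c3C4=O)nn2)O1`. It differs from compound 1 by hydrogen in place of hydroxymethyl on a saturated ring carbon. Going by the values given here, no measured step touches this part of the molecule: the only measured step concerns the amine at the end of the chain in compounds 2 and 3, and says nothing about the ring that carries the change here. Among the compounds with values here, the loss of a hydroxymethyl group on that ring has no precedent in these data, so the expectation is a step of no certain direction and of a size within the scatter.

Compound 4 is therefore expected to give about 600 nM, with a range from 250 nM to 1500 nM. This estimate means a step of a 1.2-fold lower number from compound 1 to compound 4 (0.06 log units; within the scatter), expected to stay within the scatter.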

Compound 4, half-maximal inhibitory concentration: 530 nM
For compound 4 the middle estimate is 1.1-fold (0.05 log units) above the measured one, within the range that was stated.
By their numbers in this assay, from the lowest: compounds 2 and 3 (each within the scatter of the next); then compounds 4 and 1 (each within the scatter of the next).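

In this assay, replacing hydroxymethyl with hydrogen on the saturated ring carbon gives a 1.3-fold lower number from compound 1 to compound 4 (0.11 log units; within the scatter). For the compounds shown here, this is the first measured change on the five-membered ring, and it turns the 5-(hydroxymethyl)-2,2-dimethyl-1,3-dioxolan-4-yl group into the plain 2,2-dimethyl-1,3-dioxolan-4-yl group; the hydroxymethyl group, with its hydrogen-bond donor and acceptor, can go from this place with no change in the number that stands out from repeat-to-repeat variation, although this single pair speaks only for this ring on this core. No separate measurement is available to explain this result.

Hydrogen is the only replacement shown at this ring carbon, so it remains open whether an aminomethyl group, a carboxylic acid or a longer chain such as hydroxyethyl would move the number beyond the scatter in either direction. Also open, from the compounds shown here alone, is how much the two methyl groups on the neighbouring part of the ring contribute, since a ring carrying hydrogen in their place, or the same chain ending in a free diol, would be needed to test this.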